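Swapping 1-carboxyethyl for 1-carboxycyclopropyl in compound 1

This account rests on a few compounds, and the source may have more. Where it says the series, first, only, none or still open, it means among the compounds named here.

- Compound 1 `CC(C(=O)O)c1nn(Cc2cn3cc(OCC4CC4)c(Cl)cc3n2)c2ccccc2c1=O` gives 2.44
- Compound 2 `CCOc1cc2[nH]c(Cc3nn(CC(=O)O)c(=O)c4ccccc34)nc2cc1Cl` gives 1.8
- Compound 3 `O=C(O)Cn1nc(Cn2cc3cc(OCC4CC4)c(Cl)cc3n2)c2ccccc2c1=O` gives 2.79

In a physicochemical assay for lipophilicity, at pH 7.4 (a higher number here means a more lipophilic compound, a lower number a more polar compound), compound 1 stands second of these three, with compound 3 higher and compound 2 lower, both beyond the usual scatter. Compound 4 `O=C(O)C1(c2nn(Cc3cn4cc(OCC5CC5)c(Cl)cc4n3)c3ccccc3c2=O)CC1` carries 1-carboxycyclopropyl in place of 1-carboxyethyl on an aromatic carbon and has not yet been measured. Among the measured compounds shown here, no two measured compounds differ in one place only, so no measured step can guide the expectation. In this assay the expected change is a small rise of a number 0.16 log units higher from compound 1 to compound 4 (within the scatter) that stays within the scatter. Compound 4 is estimated at 2.6 with an expected range from 2.2 to 3 on this scale.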

Compound 4, distribution coefficient: 2.46
For compound 4 the middle estimate is 0.14 log units above the measured one; measured number inside the range.
By their numbers in this assay, from the lowest: compound 2; then compounds 1 and 4 (each within the scatter of the next); then compound 3.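

In this assay, among the compounds shown here, the swap from 1-carboxyethyl to 1-carboxycyclopropyl on this aromatic carbon gives a number 0.02 log units higher from compound 1 to compound 4 (within the scatter) and is the first step in this set that changes one place only. At this position, then, the added three-membered ring of carbon does not separate the two compounds on this scale. No measurement shown offers a reason for this.

Still open, on these data alone, is how an amide or a longer chain carrying the carboxylic acid would read at this carbon in this assay. Also open, as far as these compounds go, is whether the same swap reads alike on a different core.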